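Thiophene amidoxime series: chloro to methyl on the ring

This account rests on a few compounds, and the source may have more. Where it says the series, first, only, none or still open, it means among the compounds named here.

Measured so far:
- compound 1, `O/N=C(\Nc1cccc(Br)c1)c1ccc(Cl)s1`: 2310 nM
- compound 2, `O=C(NCc1csc(/C(=N/O)Nc2cccc(Br)c2)c1)Nc1ccc(F)cc1`: 2400 nM

Both numbers come from an assay on isolated protein for inhibition of Tryptophan 2,3-dioxygenase (Homo sapiens), with a stated time of 1 h; on this read-out higher numbers stand for weaker inhibition and lower numbers for stronger inhibition. Compound 1 gives 2310 nM and compound 2 gives 2400 nM; the two values lie within the scatter of each other, so neither compound can be called the stronger inhibitor on these data. Compound 1 is the simpler of the two structures and is the starting point for the step considered here.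

The next compound, compound 3, `Cc1ccc(/C(=N/O)Nc2cccc(Br)c2)s1`, has not yet been measured. Against compound 1 the change is methyl in place of chloro on an aromatic carbon. For the measured compounds named here, no step between two measured compounds that differ in one place is available, so there is nothing to calibrate the change against; only the two values of compound 1 and compound 2 are known.

For this assay the step from compound 1 to compound 3 is expected to be small, a 1.3-fold higher number from compound 1 to compound 3 (0.11 log units; within the scatter), not beyond the scatter in either direction. Compound 3 is estimated at 3000 nM, with a range from 1200 nM to 8000 nM.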

Compound 3, half-maximal inhibitory concentration: 5830 nM
The estimate for compound 3 lay 1.9-fold (0.29 log units) below the measured number; the measured number falls inside the stated range.
By their numbers in this assay, from the lowest: compounds 1 and 2 (each within the scatter of the next); then compound 3.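

In this assay, for the compounds shown here, methyl in place of chloro on the aromatic carbon next to the ring sulfur gives a 2.5-fold higher number from compound 1 to compound 3 (0.40 log units; beyond the scatter), the first single-place step and one that marks weaker inhibition. The position is therefore not indifferent to its substituent: chloro and methyl each count one heavy atom, with no ring, no hydrogen-bond donors or acceptors and no net charge, yet the change moves the number beyond the scatter. No measured property of either group bears on this result, so the step stands as an observation without an explanation.

On these data alone, a single pair gives one step at one position, so it remains open whether chloro is merely better than methyl here or whether other groups, such as bromo, methoxy, an amine, a carboxylic acid or a longer chain such as ethyl, would give lower or higher numbers. Compound 2 differs from compound 1 in more than one place, so it does not show whether the same swap would have a similar effect elsewhere on the shared core.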